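Piperidine for Morpholine on a Thiocarbonyl Carbon

This account rests on a few compounds, and the source may have more. Where it says the series, first, only, none or still open, it means among the compounds named here.

Four compounds each carry a ring on a thiocarbonyl carbon. Compound 1 `COc1ccc2oc(CSC(=S)N3CCOCC3)cc(=O)c2c1` and compound 3 `COc1ccc2oc(CSC(=S)N3CCCCC3)cc(=O)c2c1` share one core; compound 2 `O=c1c(CSC(=S)N2CCOCC2)coc2cc(Cl)ccc12` and compound 4 `O=c1c(CSC(=S)N2CCCCC2)coc2cc(Cl)ccc12` share another, and the difference between the two cores is not broken down here. In a functional assay on HeLa cells (Homo sapiens) for antiproliferative activity, read by MTT assay, with a stated time of 72 h (on this read-out lower numbers stand for stronger inhibition and higher numbers for weaker inhibition), compound 1 gives only a limit, > 25000 nM. In this assay compound 3 gives 11900 nM. The change piperidin-1-yl in place of morpholin-4-yl on a thiocarbonyl carbon thus produced an at least 2.1-fold lower number from compound 1 to compound 3 (0.32 log units; beyond the scatter); that step is open-ended because compound 1 sits at the limit of > 25000 nM in this assay, at which 1 of the 3 values shown sits. In this assay compound 2 gives 2000 nM. Compound 4 carries the same change, (piperidin-1-yl in place of morpholin-4-yl on a thiocarbonyl carbon). Compound 4 is expected to show a 2.2-fold lower number from compound 2 to compound 4 (0.35 log units; beyond the scatter), an expectation resting on an at least 2.1-fold lower number from compound 1 to compound 3 (0.32 log units; beyond the scatter) seen with compound 3. Compound 4 is therefore estimated at 900 nM, expected to fall between 300 nM and 2500 nM.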

Compound 4, half-maximal inhibitory concentration: 440 nM
Estimate against measurement, compound 4: 2.0-fold (0.31 log units) above; measured number inside the range.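

In this assay, piperidin-1-yl in place of morpholin-4-yl on a thiocarbonyl carbon gives a 4.5-fold lower number from compound 2 to compound 4 (0.66 log units; beyond the scatter). The direction of the change therefore carries over between the two cores, but this does not show that its size stays the same: the same change on two cores in this assay, an at least 2.1-fold lower number (0.32 log units; beyond the scatter) from compound 1 to compound 3 and a 4.5-fold lower number (0.66 log units; beyond the scatter) from compound 2 to compound 4; the limit leaves it open whether they differ The value of compound 1, > 25000 nM, is a limit of the assay and not a number.

The compounds shown leave open whether the same direction would hold on a third core. They also leave open how other amines on the thiocarbonyl carbon, such as pyrrolidin-1-yl or piperazin-1-yl, would compare with piperidin-1-yl and morpholin-4-yl.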